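A few compounds are considered here, and "the series" means these few. Any claim that something is new, unique, unknown or untested is made for them only; others in the source may bear on it.

In a functional assay (Nicotiana tabacum) (on this read-out lower numbers stand for stronger inhibition and higher numbers for weaker inhibition), compound 1 `CCCNc1nc(SC)nc2ncccc12` gives 270 nM, and compound 2 `CSc1nc(Nc2ccccc2)c2cccnc2n1` gives 15900 nM, the higher of the two numbers. Compound 3 `CSc1nc(Nc2cccc([N+](=O)[O-])c2)c2cccnc2n1` differs from compound 2 by nitro in place of hydrogen on an aromatic carbon, meta to a large group. Within the data shown here, the one measured step, a 59-fold higher number from compound 1 to compound 2 (1.77 log units; beyond the scatter), is large, but it concerns phenyl in place of propyl on a nitrogen and bears only indirectly on this change. No step beyond the scatter is therefore expected in this assay, and the estimated step is a 1.3-fold lower number from compound 2 to compound 3 (0.12 log units; within the scatter). For compound 3 the expected value is 12000 nM, with an estimated range of 3500 nM to 40000 nM.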

Compound 3, half-maximal inhibitory concentration: 3550 nM
Compound 3: the middle estimate sits 3.4-fold (0.53 log units) above what was measured, and the stated range covers the measured number.
By their numbers in this assay, from the lowest: compound 1; then compound 3; then compound 2.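

In this assay nitro in place of hydrogen on an aromatic carbon, meta to a large group, gives a 4.5-fold lower number from compound 2 to compound 3 (0.65 log units; beyond the scatter) and so shows that the number responds to substitution on this six-membered aromatic ring of carbon only. The earlier step concerned only the group on the nitrogen. Nothing at hand accounts for the size of this step.

From the compounds shown here alone, whether the step belongs to nitro itself or to this place remains open. An amine, a methoxy group or chlorine on the same carbon, and nitro on other carbons of the ring, would separate the two.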